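The source may report more compounds than this note shows. Statements on the series, on what has been measured and on what is new or still open speak of the compounds shown alone.

Measured compounds:
compound 1 `O=C(O)CCc1ccc(OCC2COc3ccc(Br)cc3O2)cc1F` — 2240 nM
compound 2 `CC#C[C@@H](CC(=O)O)c1ccc(OC[C@H]2COc3ccc(Br)cc3O2)cc1` — 210 nM

In a functional assay on HEK293 cells for agonist activity at Free fatty acid receptor 1 (Homo sapiens), read by fluorescence and calcium flux, with a stated time of 10 min (on this read-out lower numbers stand for an effect already at smaller amounts and higher numbers for an effect only at larger amounts of compound), compound 1 gives 2240 nM, while compound 2 gives 210 nM in this assay. For the measured compounds named here, of the two numbers, that of compound 2 is the lower one, and the gap between the two compounds lies beyond the usual scatter of repeated measurements; no single-point step connects them, since they differ in more than one place, so only the two values themselves are known.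

Compound 3 `CC#C[C@@H](CC(=O)O)c1ccc(OC[C@H]2COc3ccc(S(C)(=O)=O)cc3O2)cc1` keeps the core of compound 2 and changes one substituent: methylsulfonyl in place of bromo on an aromatic carbon. Two hydrogen-bond acceptors enter where the bromine leaves, and the rest of the molecule is unchanged. Going by the values given here, no measured pair shows this exchange, so its effect cannot be read from the data. It is expected that the step from compound 2 to compound 3 in this assay stays close to the scatter, a 1.2-fold lower number from compound 2 to compound 3 (0.09 log units; within the scatter), with no clear direction favoured. Compound 3 is therefore estimated at 170 nM in this assay, within a range from 45 nM to 650 nM.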

Compound 3, half-maximal effective concentration: 27200 nM
Estimate against measurement, compound 3: 160-fold (2.20 log units) below, outside the stated range (above it).
By their numbers in this assay, from the lowest: compound 2; then compound 1; then compound 3.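

In this assay, the substituent on this aromatic carbon proves to matter strongly: with the rest of the molecule unchanged, methylsulfonyl in place of bromo brings a 130-fold higher number from compound 2 to compound 3 (2.11 log units; beyond the scatter). Compound 1 and compound 2 differ in more than one place, so they could not isolate this position, whereas this single exchange shows that the group here can by itself separate an effect at smaller amounts from one seen only at much larger amounts. No information given here bears on why this exchange has so large an effect.

Only bromo and methylsulfonyl are shown at this position, so it remains open how the number would respond to other groups there, such as chloro, methoxy, a nitrile or an amine. As far as these compounds go, it is also open whether the same exchange would produce a step of similar size on the core of compound 1.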